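The source may report more compounds than this note shows. Statements on the series, on what has been measured and on what is new or still open speak of the compounds shown alone.

In an ADME assay for protein binding, using equilibrium dialysis, at pH 7.4, tested at 2 uM (a higher number here means a larger unbound share of the compound, a lower number a smaller unbound share), compound 1 (`CC(C)(C)C#Cc1cc(N(C(=O)[C@H]2CC[C@H](C)CC2)[C@H]2C[C@@H](Oc3cccnc3)C2)c(C(=O)O)s1`) gives 0.04. That value lies within the scatter of compound 3 (`CC(C)N(C(=O)[C@@H]1CC[C@@H]2C[C@@H]2CC1)c1cc(C#CC(C)(C)C)sc1C(=O)O`) at 0.05, while compound 2 (`CC(C)N(c1cc(C#CC(C)(C)C)sc1C(=O)O)C(=O)[C@H]1CC[C@H](Cl)CC1`) reads higher at 0.14. Compound 4 (`CC(C)(C)C#Cc1cc(N(C(=O)[C@H]2CC[C@H](C)CC2)[C@H]2CC[C@H](O)CC2)c(C(=O)O)s1`) carries 4-hydroxycyclohexyl in place of 3-((pyridin-3-yl)oxy)cyclobutyl on an amide-type nitrogen. Among the compounds with values here, no measured step changes that place. The only one available, a 2.8-fold lower number from compound 2 to compound 3 (0.45 log units; beyond the scatter), concerns a group on a carbonyl carbon, so it offers only a guide to size. A modest rise in this assay of similar size is therefore expected, though its direction is a judgement from the structural change alone. The expected step is a 2.8-fold higher number from compound 1 to compound 4 (0.44 log units; beyond the scatter). Compound 4 is estimated at 0.11, with an expected range of 0.05 to 0.22.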

Compound 4, unbound fraction: 0.19
Estimate against measurement, compound 4: 1.7-fold (0.24 log units) below; measured number inside the range.
By their numbers in this assay, from the lowest: compounds 1 and 3 (each within the scatter of the next); then compounds 2 and 4 (each within the scatter of the next).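

In this assay, within the data shown here, 4-hydroxycyclohexyl in place of 3-((pyridin-3-yl)oxy)cyclobutyl on the amide-type nitrogen brings a 4.8-fold higher number from compound 1 to compound 4 (0.68 log units; beyond the scatter) and gives the first measured step at this place. The unbound fraction therefore responds to the group on this nitrogen, not only to the group on the carbonyl carbon. No evidence is available to explain the rise. The step changes the ring, the pyridin-3-yl ether and the hydroxyl together, so their shares stay unseparated. As far as these compounds go, whether a methoxy group or an amine on the cyclohexyl ring would read like the hydroxyl stays open.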